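This account rests on a few compounds, and the source may have more. Where it says the series, first, only, none or still open, it means among the compounds named here.

Going by the values given here, in a physicochemical assay for solubility, in phosphate buffer, at pH 7.4 (on this read-out lower numbers stand for lower solubility and higher numbers for higher solubility), no exact number is available yet for either compound tested so far. Compound 1 `C[C@@H]1CN(C(=O)OC(C)(C)C)CCN1c1ncc(OCc2ccc(S(C)(=O)=O)cc2F)cn1` reads < 5000 nM, which is a limit of the assay and not a number. Compound 2 `C[C@@H]1CN(c2ncc(F)cn2)CCN1c1ncc(OCc2ccncc2C#N)cn1` reads < 600 nM, and this too is a limit. Compound 2 therefore has no exact position on the scale, only this limit. Among the compounds with values here, no measured pair of compounds differs in one place, so no measured step shows what a single change does here.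

Compound 3 `C[C@@H]1CN(c2nc(C3CC3)no2)CCN1c1ncc(OCc2ccncc2C#N)cn1` has 3-cyclopropyl-1,2,4-oxadiazol-5-yl in place of 5-fluoropyrimidin-2-yl on an amine nitrogen in a ring, and the rest of compound 2 stays the same: 3-cyclopropyl-1,2,4-oxadiazol-5-yl in place of 5-fluoropyrimidin-2-yl on an amine nitrogen in a ring.

Within the data shown here, with no measured step as a guide, the working expectation in this assay is no change beyond the usual scatter, in either direction. The expected step is a step that the limit leaves unreadable from compound 2 to compound 3. This expectation is anchored only on compound 2 and its limit of < 600 nM. For compound 3 the estimate is 500 nM, with an expected range of 150 nM to 2500 nM.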

Compound 3, solubility: 14000 nM
For compound 3 the middle estimate is 28-fold (1.45 log units) below the measured one; the measured number lies above the stated range.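

In this assay, the group on the amine nitrogen in a ring turns out to matter: compound 3, with 3-cyclopropyl-1,2,4-oxadiazol-5-yl in place of 5-fluoropyrimidin-2-yl, gives 14000 nM, the only exact number among the compounds shown. This single swap, with the rest of the molecule unchanged, produces an at least 23-fold higher number from compound 2 to compound 3 (1.36 log units; beyond the scatter), so this one position can move the read-out far more than repeat measurements would. Compound 2 carries a limit and not a number, so the step gives only the smallest size the change can have, and the real size stays unknown: the limit of < 600 nM in this assay, at which 1 of the 3 values shown sits.

A single swap cannot separate the five-membered aromatic ring from the cyclopropyl group it carries, and the data do not say why the read-out rises. Still open, on these data alone, is whether a 3-methyl-1,2,4-oxadiazol-5-yl group or a simple acetyl group on the same nitrogen would hold this level, and whether the same swap would give a step of similar size with another group in place of the rest of the molecule.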